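Swapping an Aryl Amide for a Cyclopentyl Amide

The source may report more compounds than this note shows. Statements on the series, on what has been measured and on what is new or still open speak of the compounds shown alone.

Measured compounds:
- Compound 1, `Cc1cc(C(=O)Nc2cccc(F)c2)nn1Cc1cc(Cl)ccc1OCc1ccccc1`: 2.8
- Compound 2, `Cc1cc(C(=O)NN2CCCCC2)nn1Cc1cc(Cl)ccc1OCC(C)C`: 3.3

Both compounds were measured in a physicochemical assay for lipophilicity, at pH 7.4; on this read-out higher numbers stand for higher lipophilicity and lower numbers for lower lipophilicity. Compound 1 gives 2.8, and compound 2 gives 3.3, so compound 1 stands as the lower of the two numbers, with compound 2 sitting higher by a margin that is beyond the usual scatter. The two compounds differ in more than one place, so what their two values show is only this difference, not a step that can be traced to a single change.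

The step followed here goes from compound 1 to compound 3, `Cc1cc(NC(=O)C2CCCC2)nn1Cc1cc(Cl)ccc1OCc1ccccc1`, which has not yet been measured in this assay. The change is (cyclopentylcarbonyl)amino in place of (3-fluorophenyl)carbamoyl on an aromatic carbon. The leaving group and the entering group each carry one hydrogen-bond donor and one hydrogen-bond acceptor, and both contain one ring, one aromatic and one non-aromatic.

Going by the values given here, with no single-change step among the measured compounds to lean on, the expectation rests on the change itself. The step from compound 1 to compound 3 is expected to be small, a number 0.10 log units lower from compound 1 to compound 3 (within the scatter), most likely within the scatter, with a slight lean toward a lower number. Compound 3 is therefore estimated at 2.7, in a range from 2.2 to 3.3.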

Compound 3, distribution coefficient: 3.5
Compound 3: the middle estimate sits 0.80 log units below what was measured, outside the stated range (above it).
By their numbers in this assay, from the lowest: compound 1; then compounds 2 and 3 (each within the scatter of the next).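

In this assay, placing (cyclopentylcarbonyl)amino where (3-fluorophenyl)carbamoyl stood gives a number 0.70 log units higher from compound 1 to compound 3 (beyond the scatter), the first step among these compounds that can be traced to a single change. It shows that the read-out responds to this exchange at this aromatic carbon, even though the leaving and entering groups each carry 1 hydrogen-bond donor and 1 hydrogen-bond acceptor, so matching those counts did not keep the number in place. Nothing measured here explains why the number moved.

This one exchange alters several features together: the aromatic six-membered ring becomes a non-aromatic five-membered ring, the fluorine disappears, and the amide linking the ring to the core runs the opposite way, so the step cannot say how much each feature contributes. Going by these compounds, a benzoylamino group on the same carbon would keep the direction of the new amide with an aromatic ring, and a cyclopentylcarbamoyl group would keep the direction of the old amide with the non-aromatic ring, so these are the comparisons that remain open.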